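The compounds below may be only part of what the source reports. "The series", "measured", "known", "first", "only" and "open" are said of these compounds alone.

Measured compounds:
compound 1 `Cc1ccc(OCC(=O)N(Cc2cccs2)c2ncccn2)cc1` gives 3700 nM
compound 2 `O=C(COc1ccc2c(c1)CCC2)N(Cc1cccs1)c1ccn[nH]1` gives 0.001 nM
compound 3 `CCN(Cc1cccs1)C(=O)COc1ccc(CO)cc1` gives 21900 nM

In an assay on HEK293 cells for agonist activity at transient receptor potential cation channel subfamily M member 8 (Homo sapiens), read by fluorescence and calcium flux, with a stated time of 15 min (on this read-out lower numbers stand for an effect already at smaller amounts and higher numbers for an effect only at larger amounts of compound), compound 1 gives 3700 nM, the second highest of the three numbers. Compound 3 gives a higher number and compound 2 a much lower one; both gaps from compound 1 lie beyond the scatter. Compound 4 `Cc1ccc(OCC(=O)N(Cc2cccs2)c2nccs2)cc1` differs from compound 1 in one place: 1,3-thiazol-2-yl in place of pyrimidin-2-yl on an amide-type nitrogen. Within the data shown here, no step between measured compounds covers this change, so its size cannot be read from the data. Only a small shift is expected, and the step of a 1.3-fold lower number from compound 1 to compound 4 (0.12 log units; within the scatter) is estimated to stay within the scatter. Compound 4 is therefore expected to give 2800 nM, with a range from 700 nM to 11000 nM.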

Compound 4, half-maximal effective concentration: 2240 nM
For compound 4 the middle estimate is 1.3-fold (0.10 log units) above the measured one; the range from low to high includes it.
By their numbers in this assay, from the lowest: compound 2; then compounds 4 and 1 (each within the scatter of the next); then compound 3.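

In this assay, among these compounds, 1,3-thiazol-2-yl in place of pyrimidin-2-yl on an amide-type nitrogen gives a 1.7-fold lower number from compound 1 to compound 4 (0.22 log units; within the scatter) and is the first step measured at this position. On the core of compound 1, a five-membered aromatic ring with sulfur can thus stand here in place of a six-membered aromatic ring with two nitrogens, with no shift beyond the scatter. No measured evidence explains this result.

The compounds shown leave open how this position would respond to a non-aromatic group, such as a morpholine, or to an amino or carboxylic acid substituent on the 1,3-thiazol-2-yl ring.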